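Acetyl in Place of Benzyl: One Change Followed

The compounds below may be only part of what the source reports. "The series", "measured", "known", "first", "only" and "open" are said of these compounds alone.

Of the compounds shown here, three have so far been measured in a functional assay on 3T3-L1 cells (Mus musculus) for inhibition, with a stated time of 20 min, tested at 20 uM; a lower number here means less inhibition, a higher number more inhibition at the concentration tested (going by the name of the read-out). Compound 1 `Fc1cccc(CNCc2c[nH]c3ccccc23)c1F` gives -1.7%. Compound 2 `Cc1ccc(S(=O)(=O)N(Cc2cn(Cc3ccccc3Cl)nn2)Cc2cn(S(=O)(=O)c3ccc(C)cc3)c3ccccc23)cc1` gives -4.8%. Compound 3 `Cc1ccc(S(=O)(=O)n2cc(CN(Cc3ccccc3)Cc3cccc(F)c3F)c3ccccc32)cc1` gives -13.1%, the lowest of the three numbers; the number for compound 2 lies within the scatter of it, while the number for compound 1 lies beyond it. No two of these compounds differ from one another in a single place, so no step between measured compounds can be read off, and all three sit close to zero on the inhibition scale.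

Compound 4 `CC(=O)N(Cc1cccc(F)c1F)Cc1cn(S(=O)(=O)c2ccc(C)cc2)c2ccccc12` differs from compound 3 in one place: acetyl in place of benzyl on an amine nitrogen. For the measured compounds named here, nothing among the measured compounds speaks to this particular change, so the expectation rests only on how low all three measured numbers are. Since compound 3 gives -13.1% and the other two compounds sit near it, the step of a number 8.1 percentage points higher from compound 3 to compound 4 (within the scatter) is expected to be small, with no direction that goes beyond the scatter. Compound 4 is therefore estimated at -5%, with a range from -20% to 10%.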

Compound 4, a percentage reported as inhibition, at one concentration (the size of the read-out at that concentration, not a potency): 57.5%
Beside the measured number, compound 4's estimate is 62.5 percentage points below it; measured number above the stated range.
By their numbers in this assay, from the lowest: compounds 3, 2 and 1 (each within the scatter of the next, the first and the last beyond it); then compound 4.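

In this assay, for the compounds shown here, acetyl in place of benzyl on the amine nitrogen gives a number 70.6 percentage points higher from compound 3 to compound 4 (beyond the scatter), the first step between compounds differing in one place, and it shows that the number is highly sensitive to what sits at this position. The change takes away a six-membered aromatic ring of carbon only and 7 heavy atoms, and brings in 3 heavy atoms, a double bond outside aromatic rings and a hydrogen-bond acceptor, but this single pair cannot separate these differences and show which of them goes with the higher number. No supporting measurement is available to explain the step.

The compounds shown leave open whether the number follows the carbonyl or the loss of the benzyl ring, a question that a methyl group, a propanoyl group or a longer acyl chain on the same nitrogen could help to settle. They also leave open whether acetyl would give a similar step on another core, and, with a reading at one concentration only, how potent compound 4 is.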